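Thiosemicarbazone series: fluoro in place of cyano

A few compounds are considered here, and "the series" means these few. Any claim that something is new, unique, unknown or untested is made for them only; others in the source may bear on it.

Measured so far:
compound 1, `NC(=S)N/N=C/c1cc2cccnc2s1`: 100000 nM
compound 2, `N#Cc1ccc(NC(=S)N/N=C/c2ccc3ccccc3n2)cc1`: 23700 nM
compound 3, `CN(C)C(=S)N/N=C/c1cnc2ccccc2n1`: 170 nM

All three numbers come from a functional assay on SGC-7901 cells (Homo sapiens) for antiproliferative activity, read by sulforhodamine B assay, with a stated time of 72 h; on this read-out higher numbers stand for weaker inhibition and lower numbers for stronger inhibition. On this read-out compound 2 stands second highest of the three: compound 1 sits nearest with a number beyond the scatter above it, and compound 3 sits furthest with a number beyond the scatter below it. Within the data shown here, the three compounds differ in more than one place, so no single step among them can be read off, and nothing measured yet shows what a change on the aryl group does.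

The next compound, compound 4 `Fc1ccc(NC(=S)N/N=C/c2ccc3ccccc3n2)cc1`, differs from compound 2 in one place: fluoro in place of cyano on an aromatic carbon. Among the measured compounds shown here, no measured pair shows this kind of change, so the expectation rests on compound 2 alone. The step in this assay from compound 2 to compound 4 is expected to be small, a 1.6-fold lower number from compound 2 to compound 4 (0.20 log units; within the scatter), and it may well lie within the scatter, with a slight lean toward a lower number. On that basis compound 4 is expected to give about 15000 nM, within a range from 4000 nM to 60000 nM.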

Compound 4, half-maximal inhibitory concentration: 32300 nM
Compound 4: the middle estimate sits 2.2-fold (0.33 log units) below what was measured; low and high end bracket the measured number.
By their numbers in this assay, from the lowest: compound 3; then compounds 2 and 4 (each within the scatter of the next); then compound 1.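

In this assay, among these compounds, the change from 4-cyanophenyl to 4-fluorophenyl gives a 1.4-fold higher number from compound 2 to compound 4 (0.13 log units; within the scatter) and so provides the first single-place step, with the nitrile and the fluoro not told apart at this position on this read-out. The change removes a triple bond and a hydrogen-bond acceptor and puts a single fluorine on the same aromatic carbon, yet the two numbers stay within the scatter of each other. On this one pair, then, the level of compound 2 does not depend on that triple bond or that acceptor. No measurement at hand bears on the reason for this outcome.

On these data alone, whether an amine, a carboxylic acid or a methoxy group on the same aromatic carbon would also leave the number within the scatter stays open, as does the result of a longer chain there. The other gaps in the series cannot be read as steps, since compound 1 and compound 3 each differ from compound 2 and compound 4 in more than one place, so what sets these numbers apart remains unresolved.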